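Swapping naphthalen-1-yl for naphthalen-2-yl

A few compounds are considered here, and "the series" means these few. Any claim that something is new, unique, unknown or untested is made for them only; others in the source may bear on it.

So far, two compounds have been measured in a functional assay on HeLa cells (Homo sapiens) for antiproliferative activity, with a stated time of 5 days; on this read-out higher numbers stand for weaker inhibition and lower numbers for stronger inhibition. Compound 1 `O=C1C=CC2(C=C1)OCC(=O)N2c1nc(-c2ccc3ccccc3c2)nn1-c1ccc2ccccc2c1` gives 210 nM, and compound 2 `O=C1C=CC2(C=C1)OCC(=O)N2c1nc(-c2cccc3ccccc23)nn1-c1ccccc1` gives 70 nM. That is the lower of the two numbers, and its gap to compound 1 lies beyond the usual scatter. Compound 3 `O=C1C=CC2(C=C1)OCC(=O)N2c1nc(-c2ccc3ccccc3c2)nn1-c1ccccc1` has not yet been measured. It has the same atoms as compound 2, joined differently, with naphthalen-2-yl in place of naphthalen-1-yl on an aromatic carbon. Going by the values given here, no measured pair shows this change alone, so any expectation is rough. Compound 1 also carries naphthalen-2-yl and gives 210 nM, but it differs elsewhere too. The estimated step of a 1.6-fold higher number from compound 2 to compound 3 (0.20 log units; within the scatter) is small, towards weaker inhibition, and is expected to stay within the scatter. For compound 3 the expected value is 110 nM, with an estimated range of 40 nM to 300 nM.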

Compound 3, half-maximal inhibitory concentration: 120 nM
Beside the measured number, compound 3's estimate is 1.1-fold (0.04 log units) below it, within the range that was stated.
By their numbers in this assay, from the lowest: compounds 2, 3 and 1 (each within the scatter of the next, the first and the last beyond it).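

Swapping naphthalen-1-yl for naphthalen-2-yl on the aromatic carbon gives a 1.7-fold higher number from compound 2 to compound 3 (0.23 log units; within the scatter) in this assay, so this read-out does not clearly separate the two attachments. On the aromatic nitrogen, phenyl in place of naphthalen-2-yl gives a 1.8-fold lower number from compound 1 to compound 3 (0.24 log units; within the scatter), and so the gap between compound 1 and compound 2, which differ in two places, now divides into two single changes that each stay within the scatter. No data here on the compounds' behaviour offer an explanation for these steps.

As far as these compounds go, what an amine or a carboxylic acid in place of the naphthalen-2-yl on the aromatic carbon would do remains open. The same goes for a short alkyl chain in place of the phenyl on the aromatic nitrogen.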